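Replacing a heterocyclic ester with a nitrate on a shared core

The compounds below may be only part of what the source reports. "The series", "measured", "known", "first", "only" and "open" are said of these compounds alone.

Measured compounds:
- compound 1 `CC(=O)Oc1ccccc1C(=O)O[C@H]1CO[C@H]2[C@@H]1OC[C@H]2OC(=O)c1snnc1C`: 0.0065 h
- compound 2 `CC(=O)Oc1ccccc1C(=O)O[C@H]1CO[C@H]2[C@@H]1OC[C@H]2OC(=O)c1ccnn1C`: 0.0642 h
- compound 3 `CC(=O)Oc1ccccc1C(=O)O[C@H]1CO[C@H]2[C@@H]1OC[C@H]2OC(=O)c1cccnc1`: 0.00617 h

In an ADME assay on a cell-free system (plasma, Homo sapiens) for metabolic stability, with Plasma (Rattus norvegicus) as the target, read by HPLC, at pH 7.4 (on this read-out higher numbers stand for a longer-lived compound and lower numbers for a shorter-lived compound), compound 1 stands second highest of the three; its nearest neighbour is compound 3, whose value lies within the scatter of it, while compound 2 sits clearly higher, as the step of a 9.9-fold higher number from compound 1 to compound 2 (0.99 log units; beyond the scatter) shows. The new compound, compound 4 `CC(=O)Oc1ccccc1C(=O)O[C@H]1CO[C@H]2[C@@H]1OC[C@H]2O[N+](=O)[O-]`, differs from compound 1 in one place: nitro in place of (4-methyl-1,2,3-thiadiazol-5-yl)carbonyl on an oxygen on a saturated carbon.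

Among the compounds with values here, none of the measured steps swaps a carbonyl-bearing group for a nitro group; they only exchange one aromatic ring for another on the carbonyl carbon. Those exchanges gave a 1.1-fold lower number from compound 1 to compound 3 (0.02 log units; within the scatter) and a 10-fold lower number from compound 2 to compound 3 (1.02 log units; beyond the scatter), so the group at this position can move the half-life clearly or leave it unchanged. The rest of the core, including its other ester groups, is kept, which limits how far the number can climb. A moderate rise is therefore expected, a 4.6-fold higher number from compound 1 to compound 4 (0.66 log units; beyond the scatter), giving compound 4 an estimated 0.03 h with a range of 0.006 h to 0.15 h.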

Compound 4, half-life: 0.00314 h
Compound 4: middle estimate off by 9.6-fold (0.98 log units), on the high side, outside the stated range (below it).
By their numbers in this assay, from the lowest: compounds 4, 3 and 1 (each within the scatter of the next, the first and the last beyond it); then compound 2.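

Removing the ring-bearing ester and putting nitro on this oxygen gives no longer half-life in this assay and instead brings a 2.1-fold lower number from compound 1 to compound 4 (0.32 log units; beyond the scatter) alongside a 2.0-fold lower number from compound 3 to compound 4 (0.29 log units; within the scatter) so an aromatic ring on a carbonyl is not needed for a half-life in this short range. The real separation lies with the ester of compound 2, since the same change there gives a 20-fold lower number from compound 2 to compound 4 (1.31 log units; beyond the scatter) and the (1-methyl-1H-pyrazol-5-yl)carbonyl group remains the only one here that stands clearly apart from the others. Nothing available here explains why these groups differ.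

On these data alone, whether a free hydroxyl group or a small acetyl ester on this oxygen would approach compound 2 stays open. Also open, as far as these compounds go, is how much the other ester groups on the shared core limit the half-life.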